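The source may report more compounds than this note shows. Statements on the series, on what has been measured and on what is new or still open speak of the compounds shown alone.

Measured so far in an assay on microsomes from intestine for inhibition of acyl-CoA:cholesterol acyltransferase (Oryctolagus cuniculus); on this read-out lower numbers stand for stronger inhibition and higher numbers for weaker inhibition:
- compound 1 `Cc1cc(C)c(NC(=O)N(Cc2cc(-c3ccccc3)cs2)C2CCCCCC2)c(C)c1`: 36 nM
- compound 2 `Cc1cc(C)c(NC(=O)N(Cc2ccc(-c3n[nH]c(C)n3)cc2)C2CCCCCC2)c(C)c1`: 120 nM
- compound 3 `Cc1cc(C)c(NC(=O)N(Cc2cccc(-n3cccc3)c2)C2CCCCCC2)c(C)c1`: 20 nM

Among these three, compound 2 stands at the highest number, that is the weakest inhibition; compound 1 sits nearest to it and compound 3 furthest, both gaps lying beyond the usual scatter. The unmeasured compound 4 `Cc1cc(C)c(NC(=O)N(Cc2ccc(-n3cccn3)cc2)C2CCCCCC2)c(C)c1` arises from compound 2 by a single change: 1H-pyrazol-1-yl in place of 5-methyl-1H-1,2,4-triazol-3-yl on an aromatic carbon. Going by the values given here, no pair of measured compounds differs in exactly this way, so the step has no direct precedent. Compound 3, which carries a nitrogen-linked five-membered ring and gives 20 nM, hints that a ring without a hydrogen-bond donor may be favoured. Compound 4 is therefore expected to reach a lower number, an estimated step of a 2.7-fold lower number from compound 2 to compound 4 (0.43 log units; beyond the scatter), giving an expected 45 nM with a range from 15 nM to 130 nM.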

Compound 4, half-maximal inhibitory concentration: 70 nM
Compound 4: middle estimate off by 1.6-fold (0.19 log units), on the low side; measured number inside the range.
By their numbers in this assay, from the lowest: compounds 3, 1, 4 and 2 (each within the scatter of the next, the first and the last beyond it).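

In this assay, exchanging 5-methyl-1H-1,2,4-triazol-3-yl for 1H-pyrazol-1-yl on the aromatic carbon para to a large group gives a 1.7-fold lower number from compound 2 to compound 4 (0.23 log units; within the scatter). At this position, then, a ring with no hydrogen-bond donor and a ring with one cannot be told apart in this pair. Nothing shown accounts for this result.

The compounds shown leave open whether a different kind of group at this position, such as a carboxylic acid or a dimethylamino group, would move the number beyond the scatter. They also leave open how a plain phenyl ring would compare here.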